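The compounds below may be only part of what the source reports. "The series", "measured", "known", "first", "only" and "open" are said of these compounds alone.

Measured so far in a functional assay on CLL cells (Homo sapiens) for cytotoxicity, read by MTT assay, with a stated time of 48 h; on this read-out higher numbers stand for an effect only at larger amounts of compound and lower numbers for an effect already at smaller amounts:
- compound 1 `C=C(CC)C(=O)c1ccc(OCC(=O)Nc2nc3ccccc3s2)c(Cl)c1Cl`: 1500 nM
- compound 2 `C=C(CC)C(=O)c1ccc(OCC(=O)Nc2ccc(S(=O)(=O)O)cc2)c(Cl)c1Cl`: > 25000 nM (a limit, not a number)

Compound 2 has no number on this read-out. Its entry of > 25000 nM is only a limit of the assay. As far as these compounds go, the series therefore has a single numeric anchor, and any comparison with compound 2 stays open on one side.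

Next in line is compound 3 `C=C(CC)C(=O)c1ccc(OCC(=O)Nc2ccc(C(=O)OC)cc2)c(Cl)c1Cl`, which differs from compound 2 at one place: methoxycarbonyl in place of sulfo on an aromatic carbon. This puts methoxycarbonyl in place of sulfo on an aromatic carbon, para to a large group.

Going by the values given here, no measured pair isolates this change, so the size of the step is a judgement. Among the compounds with values here, the expectation leans on compound 1, which gives 1500 nM, the one number available. Compound 3 is expected to give a number in this assay and to move toward smaller amounts, beyond the scatter. The expected step is an at least 5.0-fold lower number from compound 2 to compound 3 (0.69 log units; beyond the scatter), though its true size remains uncertain. For compound 3 the estimated value is 5000 nM, with an expected range of 1500 nM to 17000 nM.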

Compound 3, half-maximal effective concentration: 4100 nM
For compound 3 the middle estimate is 1.2-fold (0.09 log units) above the measured one; measured number inside the range.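

In this assay, methoxycarbonyl in place of sulfo on this aromatic carbon, para to a large group, gives an at least 6.0-fold lower number from compound 2 to compound 3 (0.78 log units; beyond the scatter), the first sign in the series that the group at this position matters to the read-out. The exchange keeps the heavy-atom count and the hydrogen-bond acceptor count of the group, but it removes the hydrogen-bond donor and swaps sulfur for carbon, and this one step cannot tell which of these differences carries the change. The step has a floor on its size and no ceiling, and the entry for compound 2 is a limit, not a number: the limit of > 25000 nM in this assay, at which 1 of the 3 values shown sits.

As far as these compounds go, what a carboxylic acid, an amine or an ester with a longer chain on this same aromatic carbon would give in this assay remains open, so it cannot yet be said whether the ester itself matters or merely the absence of sulfo. Compound 1 differs from compound 3 in more than one place, which leaves the aromatic amide portion without a clean comparison.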